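Propyl on the core carbon with a free thiol

This account rests on a few compounds, and the source may have more. Where it says the series, first, only, none or still open, it means among the compounds named here.

Working notes on the series. Compound 3 `Sc1nncc2cncn12` carries a free thiol on the shared core. In a functional assay for inhibition, with Homo sapiens as the target (a lower number here means a stronger inhibitor, a higher number a weaker inhibitor), compound 3 gives > 48000 nM, which is a limit of the assay and not a number. Compound 1 `CC(C)CCSc1nncc2cncn12` carries isopentyl on the sulfur and in this assay gives 9000 nM. For the measured compounds named here, the one measured step that changes a single place is an at least 5.3-fold higher number from compound 1 to compound 3 (0.72 log units; beyond the scatter), and it concerns the sulfur substituent, not the ring carbon. Compound 2 `C=CCSc1nncc2cnc(CCC)n12` carries propyl on the ring carbon together with allyl on the sulfur. In this assay compound 2 gives > 48000 nM, again a limit of the assay. The relevant boundary is the limit of > 48000 nM in this assay, at which 2 of the 3 values shown sit, so compound 3 stands at the weak end of the numbers shown, with no number of its own.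

Compound 4 `CCCc1ncc2cnnc(S)n12` is compound 3 with propyl in place of hydrogen on an aromatic carbon. Going by the values given here, no measured step bears directly on this change. Among the compounds with values here, the only compound that already carries propyl at this place, compound 2, sits at the limit, and compound 3 sits at the limit as well. In this assay compound 4 is therefore expected to show a step that the limit leaves unreadable from compound 3 to compound 4 that stays within the scatter, most likely again reported only as a limit. The estimate for compound 4 is 60000 nM, with a range from 20000 nM to 200000 nM.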

Compound 4, half-maximal inhibitory concentration: > 48000 nM
Compound 4 ended at the assay's limit; the forecaster's own chance of this, stated with the estimate: 75%; the middle value does not contradict the limit.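

In this assay compound 4 gives > 48000 nM, a limit of the assay and not a number. The steps to compound 4 from compound 2 and from compound 3 cannot be read, because all three compounds end at a limit: the limit of > 48000 nM in this assay, at which 3 of the 4 values shown sit.

The compounds shown leave open what propyl in place of hydrogen on an aromatic carbon does with isopentyl on the sulfur, as in compound 1.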